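A few compounds are considered here, and "the series" means these few. Any claim that something is new, unique, unknown or untested is made for them only; others in the source may bear on it.

Compounds measured in an assay on ileum for antagonist activity at 5-hydroxytryptamine receptor 3A (Cavia porcellus); on this read-out lower numbers stand for stronger inhibition and higher numbers for weaker inhibition:
compound 1, `N#Cc1cccnc1N1CCN(CCCN2CCN(c3cccc(Cl)c3Cl)CC2)CC1`: 300 nM
compound 2, `N#Cc1cccnc1N1CCN(CCCN2CCN(c3ccccc3)CC2)CC1`: limit only

In this assay compound 2 gives only the limit of the assay, > 3000 nM; here the limit of > 3000 nM in this assay, at which 1 of the 2 values shown sits, applies. Compound 3, `COc1ccc(N2CCN(CCCN3CCN(c4ncccc4C#N)CC3)CC2)cc1`, differs from compound 2 by methoxy in place of hydrogen on an aromatic carbon. Among the measured compounds shown here, the one measured step on this ring, an at least 10-fold higher number from compound 1 to compound 2 (1.00 log units; beyond the scatter), shows that the substitution pattern on the phenyl matters, but it says nothing about a methoxy group in this position. Compound 3 is therefore expected to stay near compound 2, with a step of about a number no higher from compound 2 to compound 3 (the limit leaves the size open). The estimate for compound 3 is 3000 nM, within 600 nM to 15000 nM.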

Compound 3, half-maximal inhibitory concentration: 3000 nM
The estimate for compound 3 equals the measured number at the digits printed; low and high end bracket the measured number.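

Compound 3 gives 3000 nM in this assay, a measured number, and 4-methoxyphenyl in place of 2,3-dichlorophenyl gives a 10-fold higher number from compound 1 to compound 3 (1.00 log units; beyond the scatter). Compound 2 gives only a limit, > 3000 nM. Methoxy in place of hydrogen on an aromatic carbon gives a number no higher from compound 2 to compound 3 (the limit leaves the size open), so no gain or loss from methoxy can be stated: the limit of > 3000 nM in this assay, at which 1 of the 3 values shown sits.

Open, as far as these compounds go, is whether a single chlorine on the phenyl would keep the level of compound 1. Also open, from the compounds shown here alone, is how an amine or a carboxylic acid in place of the methoxy would read.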